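Carbamate replacing thioimidate on the sugar oxygen of compound 2

The source may report more compounds than this note shows. Statements on the series, on what has been measured and on what is new or still open speak of the compounds shown alone.

Going by the values given here, compound 2 `C/N=C(\S)OC[C@H]1OC(n2cnc3c(NC4CCOC4)nc(Cl)nc32)[C@H](O)[C@@H]1O` stands at the top of the two numbers so far: in an assay on DDT1 cells (Cricetulus griseus) for binding affinity to adenosine receptor A1 (Homo sapiens), read by radioligand binding (on this read-out higher numbers stand for weaker inhibition and lower numbers for stronger inhibition), compound 2 gives 71 nM, while compound 1 `C/N=C(\S)OC[C@H]1OC(n2cnc3c(NC4CCOC4)ncnc32)[C@H](O)[C@@H]1O` gives 45 nM. Among the compounds with values here, the only measured step, a 1.6-fold higher number from compound 1 to compound 2 (0.20 log units; within the scatter), is a chloro in place of hydrogen on an aromatic carbon, so the two compounds are not separated beyond the scatter.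

Compound 3 `O=C(NC1CCCC1)OC[C@H]1OC(n2cnc3c(NC4CCOC4)nc(Cl)nc32)[C@H](O)[C@@H]1O` is the next compound. Its change from compound 2 is a group of 8 heavy atoms (6 carbon, 1 nitrogen, 1 oxygen; one five-membered non-aromatic ring of carbon only) in place of a group of 4 heavy atoms (2 carbon, 1 nitrogen, 1 sulfur; no ring), on an oxygen on a saturated carbon. Within the data shown here, no measured step touches the group on the oxygen on the saturated carbon; the step from compound 1 to compound 2 lies elsewhere on the core and says nothing about this exchange. The expectation for compound 3 therefore rests on compound 2 alone, with a wide band: the expected step is a 1.1-fold higher number from compound 2 to compound 3 (0.05 log units; within the scatter), no direction being favoured. The estimate for compound 3 in this assay is 80 nM, expected to fall between 15 nM and 400 nM.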

Compound 3, inhibition constant: 226 nM
Estimate against measurement, compound 3: 2.8-fold (0.45 log units) below; the range from low to high includes it.
By their numbers in this assay, from the lowest: compounds 1 and 2 (each within the scatter of the next); then compound 3.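

Going by these compounds alone, the group on the oxygen on a saturated carbon is the first place where a measured exchange goes beyond the scatter: in this assay, cyclopentylcarbamoyl in place of the group of 4 heavy atoms gives a 3.2-fold higher number from compound 2 to compound 3 (0.50 log units; beyond the scatter), a modest step towards weaker inhibition. This position therefore responds to the exchange, whereas the chloro step on the aromatic carbon stays within the scatter. The two groups have the same hydrogen-bond donor and acceptor counts but differ in atoms and ring, and no available evidence accounts for the step.

From the compounds shown here alone, it remains open whether a methylcarbamoyl or a cyclohexylcarbamoyl group would give a number nearer compound 2 or compound 3. Going by these compounds, it is also open whether cyclopentylcarbamoyl would give a similar step with hydrogen in place of chloro on the aromatic carbon.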